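The compounds below may be only part of what the source reports. "The series", "measured", "known", "first", "only" and "open" are said of these compounds alone.

Working notes on a short acid ceramidase series. Compound 1 `O=C(NCCCCc1ccccc1)n1c(-c2ccccc2)coc1=O` and compound 2 `O=C(NCCCCc1ccccc1)n1cc(-c2ccc(Cl)cc2)oc1=O` share the same core and the same four-carbon chain to the phenyl group, and both have been measured in an assay on isolated protein for inhibition of acid ceramidase (Homo sapiens), read by LC-MS, with a stated time of 1 h; a higher number here means a weaker inhibitor, a lower number a stronger inhibitor. In this assay compound 1 gives 70 nM, and compound 2 gives 83 nM. Compound 2 thus carries the higher of the two numbers, but its gap to compound 1 lies within the scatter, so the two are read as alike.

Compound 3 `O=C(NCCCCc1ccccc1)n1cc(-c2nccs2)oc1=O` is the next compound and has not yet been measured in this assay. Its change from compound 2 is 1,3-thiazol-2-yl in place of 4-chlorophenyl on an aromatic carbon. Going by the values given here, no measured pair shows the effect of a change at this place, so the expectation rests on the closeness of compound 1 and compound 2 alone. The expected step from compound 2 to compound 3 is a 1.4-fold higher number from compound 2 to compound 3 (0.16 log units; within the scatter), a small move toward a weaker inhibitor, and compound 3 is expected to give 120 nM, within 50 nM to 300 nM.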

Compound 3, half-maximal inhibitory concentration: 59 nM
Beside the measured number, compound 3's estimate is 2.0-fold (0.31 log units) above it, within the range that was stated.
By their numbers in this assay, from the lowest: compounds 3, 1 and 2 (each within the scatter of the next).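

In this assay, going by these compounds alone, 1,3-thiazol-2-yl in place of 4-chlorophenyl on an aromatic carbon next to the ring oxygen gives a 1.4-fold lower number from compound 2 to compound 3 (0.15 log units; within the scatter), the first measured pair at this position. In this pair, a five-membered aromatic ring with 2 hetero atoms and 2 hydrogen-bond acceptors stands in place of a six-membered aromatic ring of carbon only, and the two compounds are read as alike. Nothing at hand gives a reason for this closeness.

As far as these compounds go, a single pair cannot show how far this position tolerates change, and the effect of a non-aromatic group here, such as an amine or a carboxylic acid, remains open. Also open, from the compounds shown here alone, is whether the closeness of this pair would hold with a longer chain in place of the four-carbon chain.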